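Propargyl in Place of Hydrogen on an Aromatic Nitrogen

The compounds below may be only part of what the source reports. "The series", "measured", "known", "first", "only" and "open" are said of these compounds alone.

Three compounds sharing a diethyl-substituted urea or carbamate attached to a fused two-ring aromatic core have been tested in an assay on isolated protein for inhibition of Amine oxidase [flavin-containing] A (Homo sapiens), read by fluorescence, with stated times of 10 min, 10 s and 20 min; on this read-out higher numbers stand for weaker inhibition and lower numbers for stronger inhibition. Compound 1 `CCN(CC)C(=O)Nc1ccc2[nH]ccc2c1` gives only a limit in this assay, > 100000 nM, which marks the edge of what the measurement can report rather than a number. Compound 2 `CCN(CC)C(=O)Nc1ccc2cc[nH]c2c1` gives 20400 nM in this assay, and compound 3 `CCN(CC)C(=O)Oc1ccc2[nH]ccc2c1` gives 13200 nM. Among the two measured numbers, compound 2 stands at the higher end, yet its nearest neighbour, compound 3, sits within the usual scatter of it, so the two cannot be told apart with confidence. Evidence on the steps between measured compounds is confined to one point: the limit of > 100000 nM in this assay, at which 1 of the 3 values shown sits.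

Compound 4 `C#CCn1ccc2ccc(NC(=O)N(CC)CC)cc21` has not yet been measured in this assay. It differs from compound 2 in a single place: propargyl in place of hydrogen on an aromatic nitrogen. Among the compounds with values here, no measured pair shows what this change does, so the expectation rests on compound 2 alone, whose value of 20400 nM provides the starting point. The change is expected to move the number downward, toward stronger inhibition, by a step of an 8.2-fold lower number from compound 2 to compound 4 (0.91 log units; beyond the scatter) that goes beyond the scatter. For compound 4 the estimated value is 2500 nM, with a range from 300 nM to 20000 nM.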

Compound 4, half-maximal inhibitory concentration: 4310 nM
Estimate against measurement, compound 4: 1.7-fold (0.24 log units) below, within the range that was stated.
By their numbers in this assay, from the lowest: compound 4; then compounds 3 and 2 (each within the scatter of the next). At a limit, above all of these: compound 1.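

Propargyl in place of hydrogen on the aromatic nitrogen brings a 4.7-fold lower number from compound 2 to compound 4 (0.68 log units; beyond the scatter) in this assay and so moves the number toward stronger inhibition, by a modest step. Within the data shown here, no earlier pair spoke to this change, and this one shows that the hydrogen on this nitrogen of the five-membered aromatic ring is not needed for inhibition at this level, since a group of three carbons with a triple bond can take its place and the number still falls. What the compounds shown do not offer is any measurement that would explain the step, so it stands as an observation from a single pair, with no cause attached to it.

From the compounds shown here alone, whether the step belongs to propargyl in particular stays open: a methyl group, a saturated propyl chain or a chain ending in an amine on this same nitrogen could give a similar step, a smaller one or none. Equally open, going by these compounds, is whether propargyl on the aromatic nitrogen of compound 1 or compound 3 would move the number in the same direction.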